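Compound 2 to compound 3: replacing 2-cyclopropylethynyl

This account rests on a few compounds, and the source may have more. Where it says the series, first, only, none or still open, it means among the compounds named here.

Within the data shown here, in an ADME assay (liver) for metabolic stability, with Liver microsome (Rattus norvegicus) as the target, using microsomes and NADPH, with a stated time of 30 min, tested at 1 uM (on this read-out higher numbers stand for fast clearance and lower numbers for slow clearance), compound 1 `Nc1ccc(S(=O)(=O)N2CCN(c3ncc(C(O)(C(F)(F)F)C(F)(F)F)cc3Br)CC2)cn1` gives 32 mL.min-1.g-1 and compound 2 `Nc1ccc(S(=O)(=O)N2CCN(c3ncc(C(O)(C(F)(F)F)C(F)(F)F)cc3C#CC3CC3)CC2)cn1` gives 67 mL.min-1.g-1, the higher of the two numbers so far. Compound 3 `Cn1cc(-c2cc(C(O)(C(F)(F)F)C(F)(F)F)cnc2N2CCN(S(=O)(=O)c3ccc(N)nc3)CC2)cn1` is still unmeasured and carries 1-methyl-1H-pyrazol-4-yl in place of 2-cyclopropylethynyl on an aromatic carbon, with 1-methyl-1H-pyrazol-4-yl in place of 2-cyclopropylethynyl on an aromatic carbon. Among the measured compounds shown here, only one measured step bears on this, the modest 2.1-fold higher number from compound 1 to compound 2 (0.32 log units; beyond the scatter), with 2-cyclopropylethynyl in place of bromo on the same aromatic carbon. That is a different exchange, so it offers a rough size and no firm rule. With 2-cyclopropylethynyl leaving again, a change of similar modest size is expected, towards lower numbers in this assay. The estimated step is a 2.0-fold lower number from compound 2 to compound 3 (0.31 log units; beyond the scatter). For compound 3 the expected value is 33 mL.min-1.g-1, with an estimated range of 12 mL.min-1.g-1 to 80 mL.min-1.g-1.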

Compound 3, intrinsic clearance in microsomes: 44 mL.min-1.g-1
Estimate against measurement, compound 3: 1.3-fold (0.12 log units) below; low and high end bracket the measured number.
By their numbers in this assay, from the lowest: compounds 1, 3 and 2 (each within the scatter of the next, the first and the last beyond it).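

In this assay, 1-methyl-1H-pyrazol-4-yl on the aromatic carbon ortho to a large group gives a 1.5-fold lower number from compound 2 to compound 3 (0.18 log units; within the scatter) and a 1.4-fold higher number from compound 1 to compound 3 (0.14 log units; within the scatter), so on this read-out compound 3 cannot be told apart from either neighbour at this position. Among these compounds, the one step beyond the scatter remains a 2.1-fold higher number from compound 1 to compound 2 (0.32 log units; beyond the scatter), and a five-membered aromatic ring with 2 hetero atoms and 2 hydrogen-bond acceptors, entering in place of either earlier group, adds no second such step. No measurement at hand explains any of these steps.

From the compounds shown here alone, whether an amine, a carboxylic acid or a longer chain at this carbon would move the number beyond the scatter from compound 3 stays open. Also open, going by these compounds, is whether a pyrazole without the methyl group would stay within that scatter.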